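The compounds below may be only part of what the source reports. "The series", "measured", "known", "first", "only" and "open" are said of these compounds alone.

In a functional assay on HepG2 cells (Homo sapiens) for antiproliferative activity, read by MTT assay, with a stated time of 72 h (a higher number here means a weaker inhibitor, a lower number a stronger inhibitor), three compounds sharing one core have been measured. Compound 1 `COc1ncc(-c2ccc3c(c2)N(c2ccc(C)cc2)C(=O)CO3)cc1NS(=O)(=O)c1ccc(F)cc1` gives 28300 nM. Compound 2 `COc1ccc(N2C(=O)COc3ccc(-c4cnc(Cl)c(NS(=O)(=O)c5ccc(F)cc5)c4)cc32)cc1` reads > 40000 nM, which is a limit of the assay and not a number. Compound 3 `COc1ncc(-c2ccc3c(c2)N(C2CCCCC2)C(=O)CO3)cc1NS(=O)(=O)c1ccc(F)cc1` reads > 40000 nM, also a limit and not a number. That places it at the limit of > 40000 nM in this assay, at which 2 of the 3 values shown sit.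

Compound 4 `COc1ccc(N2C(=O)COc3ccc(-c4cnc(OC)c(NS(=O)(=O)c5ccc(F)cc5)c4)cc32)cc1` has 4-methoxyphenyl in place of the cyclohexyl of compound 3, on an amide-type nitrogen in a ring: 4-methoxyphenyl in place of cyclohexyl on an amide-type nitrogen in a ring. Among the compounds with values here, one measured step bears directly on this place: cyclohexyl in place of 4-methylphenyl gave an at least 1.4-fold higher number from compound 1 to compound 3 (0.15 log units; that floor lies within the scatter). As far as these compounds go, that figure is only a floor, so the true size of the step remains unknown. Compound 2 also carries 4-methoxyphenyl, yet it reads only a limit, which argues for caution.

A small move towards a lower number, meaning a somewhat stronger inhibitor, is therefore expected, and the expected step is an at least 1.4-fold lower number from compound 3 to compound 4 (0.15 log units; that floor lies within the scatter). The estimate for compound 4 is 28000 nM, within an expected range of 14000 nM to 40000 nM.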

Compound 4, half-maximal inhibitory concentration: 13100 nM
For compound 4 the middle estimate is 2.1-fold (0.33 log units) above the measured one, and the stated range ends above it.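

In this assay the place on the amide-type nitrogen now shows a step beyond the scatter: 4-methoxyphenyl in place of cyclohexyl gives an at least 3.0-fold lower number from compound 3 to compound 4 (0.48 log units; beyond the scatter) and so separates these two groups, which the earlier step at this place could not do. Methoxy in place of methyl on an aromatic carbon gives a 2.2-fold lower number from compound 1 to compound 4 (0.33 log units; beyond the scatter) and shows that two aromatic groups at this place can also differ, while methoxy in place of chloro on an aromatic carbon gives an at least 3.0-fold lower number from compound 2 to compound 4 (0.48 log units; beyond the scatter) and shows that 4-methoxyphenyl alone does not secure the lower number. The steps from compound 2 and compound 3 are only floors, because each of these compounds reads a limit of the assay and not a number: the limit of > 40000 nM in this assay, at which 2 of the 4 values shown sit.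

As far as these compounds go, the true size of those two steps stays unknown. Also open, from the compounds shown here alone, is how an amine, a carboxylic acid or a longer chain in place of the methoxy on 4-methoxyphenyl would read.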